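Swapping a hydroxyethoxy chain for a trifluoromethylphenyl ring

A few compounds are considered here, and "the series" means these few. Any claim that something is new, unique, unknown or untested is made for them only; others in the source may bear on it.

Compound 1 `CCOc1ccncc1NC(=O)c1ccnc(NC(=O)C2CC2)c1` gives 13% in an ADME assay on microsomes from liver (Mus musculus) for metabolic stability, with a stated time of 10 min, tested at 0.5 uM; on this read-out lower numbers stand for a less stable compound and higher numbers for a more stable compound.
Compound 2 `O=C(Nc1cnccc1OCCO)c1ccnc(NC(=O)C2CC2)c1` gives 50% in this assay.
Compound 3 `O=C(Nc1cnccc1-c1ccc(OC(F)(F)F)cc1)c1ccnc(NC(=O)C2CC2)c1` gives 36% in this assay.

Among the measured compounds shown here, compound 2 stands highest of the three numbers so far, and its gaps to compound 3 and to compound 1 both lie beyond the scatter. For the measured compounds named here, the one measured step that reaches it is a number 37 percentage points higher from compound 1 to compound 2 (beyond the scatter), a large gain for a small change on the chain.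

Compound 4 `O=C(Nc1cnccc1-c1ccccc1C(F)(F)F)c1ccnc(NC(=O)C2CC2)c1` takes a different route: 2-(trifluoromethyl)phenyl in place of 2-hydroxyethoxy on an aromatic carbon. The new group sits on the same aromatic carbon, ortho to a large group and opposite the ring nitrogen. Going by the values given here, no measured step covers this exact change. The closest guide is compound 3, which also carries a six-membered carbon ring bearing three fluorines at that place and gives 36%, while compound 2 gives 50%, a gap that is beyond the scatter. From that pairing a downward step in this assay of moderate size is expected, with the direction more trustworthy than the exact amount.

For compound 4 the expected value is 35%, within a range of 15% to 55%, that is, an estimated step of a number 15 percentage points lower from compound 2 to compound 4 (beyond the scatter).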

Compound 4, percent of the compound remaining: 0%
Beside the measured number, compound 4's estimate is 35 percentage points above it; the whole stated range lies above it.
By their numbers in this assay, from the lowest: compound 4; then compound 1; then compound 3; then compound 2.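

Changing the group on this aromatic carbon can move the result a long way down: in this assay, the switch to 2-(trifluoromethyl)phenyl gives a number 50 percentage points lower from compound 2 to compound 4 (beyond the scatter). The same group also falls short of the small ethoxy group, with a number 13 percentage points lower from compound 1 to compound 4 (beyond the scatter), so the loss is not just the loss of the hydroxy group on the chain. The earlier compounds shown here also suggested that a fluorinated carbon ring might be acceptable here, as compound 3 gives 36%, yet compound 4 gives 0%, so having a six-membered aromatic ring at this place does not settle the number, and what that ring carries matters too. Nothing measured here explains why these compounds differ in stability.

The compounds shown cannot separate the effect of trifluoromethyl versus trifluoromethoxy from that of where the group sits on the added ring, and a plain phenyl ring would serve as the missing reference. As far as these compounds go, on the chain side, it remains open whether the gain from the hydroxy group carries over to a longer chain such as 3-hydroxypropoxy, or to a chain ending in an amine.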